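The compounds below may be only part of what the source reports. "The series", "measured", "known", "first", "only" and "open" are said of these compounds alone.

In a functional assay on HL-60 cells (Homo sapiens) for cytotoxicity, read by WST assay, with a stated time of 48 h (a higher number here means that more compound is needed for the effect, a lower number that less compound is needed), the three measured compounds stand as follows:

compound 1, `O=C1OC[C@H](Cc2ccc(O)cc2)[C@H]1Cc1ccc(Cl)c(Cl)c1`, gives 37000 nM;
compound 2, `COc1ccc(C[C@H]2COC(=O)[C@@H]2Cc2ccc(Cl)c(Cl)c2)cc1`, gives 37000 nM;
compound 3, `COc1ccc(C[C@H]2COC[C@@H]2Cc2ccc(Cl)c(Cl)c2)cc1O`, gives 33000 nM.

Compound 4, `COc1ccc(C[C@H]2COC[C@@H]2Cc2ccc(Cl)c(Cl)c2)cc1OC`, has not yet been measured in this assay. The change that leads from compound 3 to compound 4 is methyl in place of hydrogen on an oxygen on an aromatic ring. The same kind of change has already been measured once, from compound 1 to compound 2, where it is methyl in place of hydrogen on an oxygen on an aromatic ring; the step it made there is no change at the digits printed from compound 1 to compound 2 (within the scatter). The two pairs sit on different cores, and the difference between the core of compound 1 and the core of compound 3 is not broken down here, so the earlier step carries over only as an indication of the same kind of change.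

On that basis compound 4 is expected to sit close to compound 3 in this assay, with an estimated step of no change at the digits printed from compound 3 to compound 4 (within the scatter), because the measured step of no change at the digits printed from compound 1 to compound 2 (within the scatter) shows no change for this kind of change. The estimated value for compound 4 is therefore 33000 nM, between 15000 nM and 75000 nM.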

Compound 4, half-maximal effective concentration: 16000 nM
Compound 4: middle estimate off by 2.1-fold (0.31 log units), on the high side; measured number inside the range.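

In this assay, methyl in place of hydrogen on an oxygen on an aromatic ring gives a 2.1-fold lower number from compound 3 to compound 4 (0.31 log units; beyond the scatter), whereas the same change on the core of compound 1 gives no change at the digits printed from compound 1 to compound 2 (within the scatter). Set side by side, the two steps cannot be told apart: the same change on two cores in this assay, no change at the digits printed (within the scatter) from compound 1 to compound 2 and a 2.1-fold lower number (0.31 log units; beyond the scatter) from compound 3 to compound 4, 2.1-fold (0.31 log units) apart, within the scatter of two such steps. This shows that the change carries from the core of compound 1 to the core of compound 3 without a measurable difference between the two steps, but two pairs do not show that the cores respond alike, and they do not explain why only the second step lies beyond the scatter.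

The compounds shown carry only hydrogen or methyl on that oxygen, so the outcome with a longer chain there, or with an amine or a carboxylic acid in place of the hydroxy group, remains open. On these data alone, whether the step from hydroxy to methoxy would hold on any further core also stays open.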